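The compounds below may be only part of what the source reports. "The series", "measured", "known", "first", "only" and "open" are said of these compounds alone.

In a functional assay for inhibition, with Rattus norvegicus as the target (on this read-out higher numbers stand for weaker inhibition and lower numbers for stronger inhibition), compound 3 `CC(C)/N=c1\c(O)c(O)\c1=N/c1ccc(C#N)cc1` gives 13700 nM, the highest number of the three measured compounds and so the weakest inhibitor among them. Compound 2 `CC(C)C(C)/N=c1\c(O)c(O)\c1=N/c1ccc(C#N)cc1` gives 1900 nM, and compound 1 `CC(/N=c1\c(O)c(O)\c1=N/c1ccc(C#N)cc1)C(C)(C)C` gives 520 nM.

Compound 4 `Cc1ccc(C(C)/N=c2\c(O)c(O)\c2=N/c2ccc(C#N)cc2)cc1` differs from compound 3 in one place: 4-methylphenyl in place of methyl on a saturated chain carbon bound to a double-bonded nitrogen and a saturated chain carbon. The swap falls on the saturated chain carbon bound to the double-bonded nitrogen, the same carbon that changes in two measured steps. One is modest, a 7.2-fold higher number from compound 2 to compound 3 (0.86 log units; beyond the scatter), and the other is large, a 26-fold higher number from compound 1 to compound 3 (1.42 log units; beyond the scatter). Read in reverse, both show that replacing methyl at this carbon with a group of more carbons gave a lower number. The modest 3.7-fold higher number from compound 1 to compound 2 (0.56 log units; beyond the scatter) runs the same way, and none of the three compounds goes against this trend. Still, all three carry saturated chains at this carbon, so the data do not show what an aromatic ring does here, and the trend is only a loose guide.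

The estimated move is an 11-fold lower number from compound 3 to compound 4 (1.06 log units; beyond the scatter), toward a lower number and stronger inhibition, and it is expected to be modest to large. Compound 4 is expected at about 1200 nM, with an estimated range from 200 nM to 6000 nM.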

Compound 4, half-maximal inhibitory concentration: > 30000 nM
Compound 4: no number, only a limit (the forecaster's own chance of this, stated with the estimate: 3%); middle value at least 25-fold (1.39 log units) from the limit.
By their numbers in this assay, from the lowest: compound 1; then compound 2; then compound 3. At a limit, above all of these: compound 4.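

In this assay compound 4 gives no number, only a limit of the assay: the limit of > 30000 nM in this assay, at which 1 of the 4 values shown sits. Even so, the limit is enough to show that putting 4-methylphenyl in place of methyl at this carbon weakens inhibition, with an at least 2.1-fold higher number from compound 3 to compound 4 (0.34 log units; beyond the scatter), and the gap is larger against the two compounds with bigger saturated chains, with an at least 15-fold higher number from compound 2 to compound 4 (1.19 log units; beyond the scatter) and an at least 57-fold higher number from compound 1 to compound 4 (1.76 log units; beyond the scatter). The earlier compounds linked more carbons at the saturated chain carbon bound to the double-bonded nitrogen with a lower number, but compound 4 goes against that trend, so among these compounds it holds only for saturated chains and a carbon count alone is a poor guide at this position.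

The compounds shown leave open whether the weak result belongs to the aromatic ring itself or to the methyl on it, a question that a plain phenyl group would help to settle. They also leave open whether a saturated ring such as cyclohexyl would behave like the branched chains or like 4-methylphenyl, and how weak compound 4 really is beyond its limit.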